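This account rests on a few compounds, and the source may have more. Where it says the series, first, only, none or still open, it means among the compounds named here.

Working notes on the series in a functional assay on A549 cells (Homo sapiens) for inhibition, read by CCK-8 assay, with a stated time of 72 h, tested at 2 uM; a higher number here means more inhibition of growth at the concentration tested, a lower number less inhibition of growth: compound 1 `COc1ccc(SCc2ccc(C(=O)Nc3ccccc3N)cc2)cc1` gives 45.7%, compound 2 `Nc1ccccc1NC(=O)c1ccc(CSCCc2ccccc2)cc1` gives 44.9% and compound 3 `Nc1ccccc1NC(=O)c1ccc(CSc2ccc(F)cc2)cc1` gives 43.4%, which places compound 3 within the scatter of both others. Next is compound 4 `Cc1cc(C)cc(SCc2ccc(C(=O)Nc3ccccc3N)cc2)c1`, with 3,5-dimethylphenyl in place of 4-fluorophenyl on a sulfur. The measured steps that exchange the group on that sulfur are small: a number 0.8 percentage points lower from compound 1 to compound 2 (within the scatter), a number 2.3 percentage points lower from compound 1 to compound 3 (within the scatter) and a number 1.5 percentage points lower from compound 2 to compound 3 (within the scatter), all within the scatter. Going by the values given here, no measured compound carries 3,5-dimethylphenyl, so these steps are only a guide, and no shift beyond the scatter is expected in this assay. The expected change is a number 1.6 percentage points higher from compound 3 to compound 4 (within the scatter). The estimate for compound 4 is 45%, with an expected range of 35% to 56%.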

Compound 4, percent growth inhibition at one concentration: 33.3%
Compound 4: middle estimate off by 11.7 percentage points, on the high side; the whole stated range lies above it.
By their numbers in this assay, from the lowest: compound 4; then compounds 3, 2 and 1 (each within the scatter of the next).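

Going by these compounds alone, at this position on the sulfur, the group now makes a difference in this assay: 3,5-dimethylphenyl gives a number 10.1 percentage points lower from compound 3 to compound 4 (beyond the scatter) and a number 11.6 percentage points lower from compound 2 to compound 4 (beyond the scatter) and a number 12.4 percentage points lower from compound 1 to compound 4 (beyond the scatter) and these are the first exchanges here to go beyond the scatter. The position therefore does not accept every aryl group equally, although 4-fluorophenyl, 4-methoxyphenyl and phenethyl remain within the scatter of one another. No available evidence bears on this drop. Open, from the compounds shown here alone, is whether one methyl group alone gives the same step, and how an amine or a carboxylic acid on that aromatic ring would read.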